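From a 4-nitrobenzyl group to an octyl chain

The source may report more compounds than this note shows. Statements on the series, on what has been measured and on what is new or still open speak of the compounds shown alone.

In a functional assay on IMR-32 cells (Homo sapiens) for antiproliferative activity, read by MTT assay (on this read-out lower numbers stand for stronger inhibition and higher numbers for weaker inhibition), compound 3 (`CC1(C)CCc2cc(C(=O)/C=C/c3ccc(OCc4cn(Cc5ccc([N+](=O)[O-])cc5)nn4)cc3)c(O)cc2O1`) gives 108000 nM as its result. Among the compounds with values here, the only other number comes from compound 1 (`CC1(C)CCc2cc(C(=O)/C=C/c3ccc(OCc4cn(-c5ccc(Cl)cc5)nn4)cc3)c(O)cc2O1`) at 92100 nM on the same scale, and the two cannot be told apart. A close relative, compound 2 (`COc1ccc(-n2cc(COc3ccc(/C=C/C(=O)c4cc5c(cc4O)OC(C)(C)CC5)cc3)nn2)c([N+](=O)[O-])c1`), is recorded as "not active" (no number reported) with no number attached. Compound 4 (`CCCCCCCCn1cc(COc2ccc(/C=C/C(=O)c3cc4c(cc3O)OC(C)(C)CC4)cc2)nn1`) has not been measured yet. Its difference from compound 3 is heptyl in place of 4-nitrophenyl on a saturated chain carbon bound to an aromatic nitrogen and reads, more simply, as 4-nitrobenzyl to octyl.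

Within the data shown here, only one measured step offers guidance. It is a 1.2-fold higher number from compound 1 to compound 3 (0.07 log units; within the scatter) and stays within the scatter, but it swaps one ring-bearing group for another. Among the measured compounds shown here, no compound with an octyl group has a measured value, so this guide is thin. No change beyond the scatter is expected in this assay with an estimated 1.2-fold lower number from compound 3 to compound 4 (0.08 log units; within the scatter) and no firm direction. For compound 4 the estimated value is 90000 nM with an expected range from 30000 nM to 250000 nM in this assay.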

Compound 4, half-maximal inhibitory concentration: 7090 nM
Compound 4: the middle estimate sits 13-fold (1.10 log units) above what was measured, and the stated range ends above it.
By their numbers in this assay, from the lowest: compound 4; then compounds 1 and 3 (each within the scatter of the next).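

In this assay, 4-nitrobenzyl and 4-chlorophenyl, both ring-bearing groups, left the numbers of compound 1 and compound 3 within the scatter of each other, so this position seemed insensitive to change. The octyl chain changes that picture: exchanging 4-nitrobenzyl for octyl gives a 15-fold lower number from compound 3 to compound 4 (1.18 log units; beyond the scatter), and octyl in place of 4-chlorophenyl on the aromatic nitrogen gives a 13-fold lower number from compound 1 to compound 4 (1.11 log units; beyond the scatter), both large and beyond the scatter. No measurement available here accounts for this difference.

Compound 4 is the only compound shown with a ring-free chain, so its result cannot separate the effect of octyl in particular from that of removing the ring. As far as these compounds go, whether a butyl group, a longer chain, or an octyl chain ending in an amine or a carboxylic acid would give a similar number remains open.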